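A few compounds are considered here, and "the series" means these few. Any claim that something is new, unique, unknown or untested is made for them only; others in the source may bear on it.

In an ADME assay on microsomes from liver (Homo sapiens) for metabolic stability (a higher number here means faster removal of the compound, a lower number slower removal), compound 1 (`Cc1cnc(C(=O)N[C@H]2CCOC[C@@H]2O)cc1Cc1ccc(-n2cccn2)cc1`) gives < 8 mL/min/kg, which is a limit of the assay and not a number. Compound 3 (`O=C(N[C@H]1CCOC[C@@H]1O)c1cc(Cc2ccc(-n3cccn3)cc2)ccn1`) gives < 8 mL/min/kg, also a limit. The methyl change therefore leaves a step that the two limits leave unreadable from compound 1 to compound 3. Compound 2 (`Cc1cnc(C(=O)N[C@H]2CCCC[C@@H]2O)cc1Cc1ccc(-n2cccn2)cc1`) gives 20 mL/min/kg, and the step is an at least 2.5-fold higher number from compound 1 to compound 2 (0.39 log units; beyond the scatter), but it changes another part of the molecule. Compound 4 (`Cc1cnc(C(=O)N[C@H]2CCOC[C@@H]2O)cc1Cc1ccc(-c2cscn2)cc1`) carries 1,3-thiazol-4-yl in place of 1H-pyrazol-1-yl on an aromatic carbon. Going by the values given here, no measured step touches this group, so only a small shift in this assay is expected, and the expected step is an at least 1.1-fold higher number from compound 1 to compound 4 (0.05 log units; that floor lies within the scatter). For compound 4 the estimated clearance is 9 mL/min/kg, with an expected range of 6 mL/min/kg to 18 mL/min/kg.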

Compound 4, clearance: < 8 mL/min/kg
Compound 4: only a limit was reported; the forecaster's own chance of this, stated with the estimate: 45%; middle value at least 1.1-fold (0.05 log units) away from the limit.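

The step from compound 1 to compound 4 cannot be read, since each gives only a limit of the assay and not a number: the limit of < 8 mL/min/kg in this assay, at which 3 of the 4 values shown sit. The compounds shown leave open whether 1,3-thiazol-4-yl or 1H-pyrazol-1-yl gives slower removal.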